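Series notes: isopropoxy to (ethylcarbamoyl)amino on the core

The compounds below may be only part of what the source reports. "The series", "measured", "known", "first", "only" and "open" are said of these compounds alone.

Measured so far in an assay on isolated protein (strain Sprague-Dawley) for inhibition of Amine oxidase [flavin-containing] A (Rattus norvegicus), read by spectrophotometry, with a stated time of 5 min, tested at 10 uM; on this read-out higher numbers stand for more inhibition at the one concentration tested (going by the name of the read-out) and lower numbers for less inhibition:
compound 1 `O=c1cc(O)c2ccc(OCc3cccc(Br)c3)cc2o1` gives 0%;
compound 2 `COc1cc(=O)oc2cc(OCc3cccc(F)c3)ccc12` gives 49%;
compound 3 `CC(C)Oc1cc(=O)oc2cc(OCc3cccc(Cl)c3)ccc12` gives 3%.

Compound 3 stands close to compound 1, the two within the scatter of each other, and far below compound 2, a gap beyond the scatter. Compound 4 `CCNC(=O)Nc1cc(=O)oc2cc(OCc3cccc(Cl)c3)ccc12` differs from compound 3 in one place: (ethylcarbamoyl)amino in place of isopropoxy on an aromatic carbon. Among the compounds with values here, no measured pair shows this exchange, so nothing in the numbers so far tells its direction. Compound 3 sits at 3% in this assay, a low starting point. The step of a number 7 percentage points higher from compound 3 to compound 4 (within the scatter) is expected to be small, a modest rise at most within or just beyond the scatter. Compound 4 is expected to give 10%, in the range 0% to 35%.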

Compound 4, a percentage reported as inhibition, at one concentration (the size of the read-out at that concentration, not a potency): 0%
Compound 4: the middle estimate sits 10 percentage points above what was measured; measured number inside the range.
By their numbers in this assay, from the lowest: compounds 1, 4 and 3 (each within the scatter of the next); then compound 2.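

In this assay the exchange of isopropoxy for (ethylcarbamoyl)amino on this aromatic carbon, opposite the ring oxygen, gives a number 3 percentage points lower from compound 3 to compound 4 (within the scatter) and so leaves inhibition low at the one concentration tested. At this position the two groups are not told apart by this read-out, despite the larger size and added hydrogen-bond donors of the entering group. No measurement on hand accounts for this result.

Open, from the compounds shown here alone, is whether a plain amine or a carboxylic acid on this carbon would read differently in this assay.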